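The source may hold more compounds than are shown below. What is called first, only, known or untested is meant among the compounds shown, and "the series" means these compounds.

Measured so far in an ADME assay on Vero 76 cells (Chlorocebus sabaeus) for cytotoxicity, read by crystal violet staining, with a stated time of 96 h (a higher number here means that more compound is tolerated, a lower number that less compound is tolerated), are:
- compound 1 `FC(F)(F)c1cccc(NC(=S)Nc2ccc(I)cc2)c1` with 9500 nM
- compound 2 `Fc1ccccc1NC(=S)Nc1cccc(C(F)(F)F)c1` with 64000 nM
- compound 3 `Fc1cccc(NC(=S)Nc2cccc(C(F)(F)F)c2)c1` with 20000 nM

Compound 3 stands second highest of the three, as the steps (a 2.1-fold higher number from compound 1 to compound 3 (0.32 log units; beyond the scatter)) and (a 3.2-fold lower number from compound 2 to compound 3 (0.51 log units; beyond the scatter)) show. Next comes compound 4 `FC(F)(F)c1cccc(NC(=S)NCc2ccco2)c1` with the change (furan-2-yl)methyl in place of 3-fluorophenyl on an amide-type nitrogen in which (furan-2-yl)methyl replaces 3-fluorophenyl on an amide-type nitrogen. Going by the values given here, no measured step makes this exact exchange. The closest evidence is the two steps above and (a 6.7-fold higher number from compound 1 to compound 2 (0.83 log units; beyond the scatter)) on that nitrogen, all modest. Compound 2 at (64000 nM) shows that a change there can raise the number, so the direction is only tentatively upward. The expected step is modest (a 1.8-fold higher number from compound 3 to compound 4 (0.24 log units; within the scatter)) and carries wide uncertainty. For compound 4 the estimated value is 35000 nM with an expected range from 12000 nM to 100000 nM as a working figure.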

Compound 4, half-maximal cytotoxic concentration: 50000 nM
The estimate for compound 4 lay 1.4-fold (0.15 log units) below the measured number; the measured number falls inside the stated range.
By their numbers in this assay, from the lowest: compound 1; then compound 3; then compounds 4 and 2 (each within the scatter of the next).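

In this assay, going by these compounds alone, (furan-2-yl)methyl is the first group on this amide-type nitrogen that is not a directly attached phenyl ring, and it gives a 2.5-fold higher number from compound 3 to compound 4 (0.40 log units; beyond the scatter) and a 5.3-fold higher number from compound 1 to compound 4 (0.72 log units; beyond the scatter). Against 2-fluorophenyl the exchange gives a 1.3-fold lower number from compound 2 to compound 4 (0.11 log units; within the scatter), so these two different groups cannot be told apart here. No measured evidence accounts for these steps. On these data alone, it remains open whether the number follows the furan-2-yl ring or the methyl link; a benzyl group or a longer chain on this nitrogen would bear on that.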